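The source may report more compounds than this note shows. Statements on the series, on what has been measured and on what is new or still open speak of the compounds shown alone.

Compound 1, `NS(=O)(=O)c1ccc(-n2nc(Nc3ccccc3)c3c(=O)n(-c4ccccc4)c(Nc4ccccc4)nc32)cc1`, is the starting point of this small series. In a functional assay on the whole organism (strain Wistar albino) for inhibition, with Rattus norvegicus as the target, read by paw edema, with a stated time of 3 h, at a dose of 25 mg/kg by the oral route (on this read-out higher numbers stand for more inhibition at the one dose given (going by the name of the read-out) and lower numbers for less inhibition), compound 1 gives 39.7%. Compound 2, `NS(=O)(=O)c1ccc(-n2nc(Nc3ccc([N+](=O)[O-])cc3)c3c(=O)n(-c4ccccc4)c(Nc4ccccc4)nc32)cc1`, carries one added group, (nitro in place of hydrogen on an aromatic carbon), and in this assay compound 2 gives 39.1%. Among the compounds with values here, the step of a number 0.6 percentage points lower from compound 1 to compound 2 (within the scatter) is the only measured example of this change, and it is too small to be called a real difference.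

Compound 3, `O=c1c2c(Nc3ccc(Cl)cc3)nn(-c3ccccc3)c2nc(Nc2ccccc2)n1-c1ccccc1`, has a different core, and the difference between its core and that of compound 1 is not broken down here. In this assay compound 3 gives 28.7%, the lowest of the three measured numbers, lying beyond the scatter below both compound 1 and compound 2.

Compound 4, `O=c1c2c(Nc3ccc(Cl)cc3)nn(-c3ccc([N+](=O)[O-])cc3)c2nc(Nc2ccccc2)n1-c1ccccc1`, has not been measured. It differs from compound 3 by nitro in place of hydrogen on an aromatic carbon. The place is worded the same as for the change from compound 1 to compound 2, so this is the same change, although one bond further out the earlier one also read anilino to (4-nitrophenyl)amino, while here it reads only phenyl to 4-nitrophenyl.

Because the step of a number 0.6 percentage points lower from compound 1 to compound 2 (within the scatter) was within the scatter, the step of a number 0.3 percentage points higher from compound 3 to compound 4 (within the scatter) is expected to be equally small. Compound 4 is therefore estimated at 29% in this assay, with a likely range from 19% to 40%.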

Compound 4, a percentage reported as inhibition, in the whole organism at one dose (the size of the read-out at that dose, not a potency): 20.6%
Compound 4: the middle estimate sits 8.4 percentage points above what was measured; measured number inside the range.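

In this assay, the new step for nitro in place of hydrogen on an aromatic carbon is a number 8.1 percentage points lower from compound 3 to compound 4 (within the scatter) and, like the earlier step, it cannot be told apart from the ordinary variation between repeated measurements. The two cores therefore give steps that agree as far as this assay can tell, and in both cases the change shows no clear effect on the read-out: the same change on two cores in this assay, a number 0.6 percentage points lower (within the scatter) from compound 1 to compound 2 and a number 8.1 percentage points lower (within the scatter) from compound 3 to compound 4, 7.5 percentage points apart, within the scatter of two such steps. This shows only that nothing in these two pairs speaks against carrying the change from one core to the other; it does not show that the change is without effect on every core, since two pairs are few, the scatter is wide enough to hide a modest real effect, and the added group stands on a different part of the molecule in each pair, as (4-nitrophenyl)amino in one and 4-nitrophenyl in the other.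

The compounds shown leave open what an amine, a methoxy group or a carboxylic acid would do in the same place on that ring. They also leave open how the nitro step would read on a third core, or at doses other than the single one used here.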